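Aryl amide cinnamate series: acrylic acid variant at the benzyl ring

The source may hold more compounds than are shown below. What is called first, only, known or untested is meant among the compounds shown, and "the series" means these compounds.

Measured so far:
compound 1 `COC(=O)/C=C/c1cccc(N(Cc2cccc(Br)c2)C(=O)C2CCCCC2)c1` — > 1000 nM
compound 2 `COC(=O)/C=C/c1cccc(N(Cc2ccc(-c3cccc(C(C)=O)c3)cc2)C(=O)C2CCCCC2)c1` — 227 nM

Compound 1 `COC(=O)/C=C/c1cccc(N(Cc2cccc(Br)c2)C(=O)C2CCCCC2)c1` gives only a limit in an assay on isolated protein with Bile acid receptor (Homo sapiens) as the target (a lower number here means that less compound is needed, a higher number that more compound is needed for the effect), > 1000 nM. Among the compounds with values here, compound 2 `COC(=O)/C=C/c1cccc(N(Cc2ccc(-c3cccc(C(C)=O)c3)cc2)C(=O)C2CCCCC2)c1` is the only numbered value shown, at 227 nM. Compound 3 `COC(=O)/C=C/c1cccc(N(Cc2ccc(/C=C/C(=O)O)cc2)C(=O)C2CCCCC2)c1` differs from compound 2 by 2-carboxyethenyl in place of 3-acetylphenyl on an aromatic carbon, para to a large group. Within the data shown here, no measured step between these two is available, so the size and direction of the change cannot be read from the data. The step from compound 2 to compound 3 is expected to be small, a 1.3-fold higher number from compound 2 to compound 3 (0.12 log units; within the scatter), within or near the scatter. For compound 3 the expected value in this assay is 300 nM, with a range from 60 nM to 2000 nM.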

Compound 3, half-maximal effective concentration: > 1000 nM
Compound 3: only a limit was reported (the forecaster's own chance of this, stated with the estimate: 25%); at least 3.3-fold (0.52 log units) between middle value and limit.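

At the aromatic carbon para to a large group, 2-carboxyethenyl in place of 3-acetylphenyl is not a neutral exchange in this assay: it gives an at least 4.4-fold higher number from compound 2 to compound 3 (0.64 log units; beyond the scatter). This position therefore responds to the group it carries, and among the compounds shown only the 3-acetylphenyl of compound 2 gives a number rather than a limit. The steps involving only limits cannot be read.

Going by these compounds, a 3-carboxyphenyl or 3-aminophenyl group here would separate the contribution of the aromatic ring from that of the side chain, and this remains open. How far compound 3 lies beyond its limit also remains open: the limit of > 1000 nM in this assay, at which 2 of the 3 values shown sit.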